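The source may hold more compounds than are shown below. What is called first, only, known or untested is meant among the compounds shown, and "the series" means these compounds.

Compound 1 `CN1C[C@H](C(=O)Nc2ccc(F)cc2)[C@@H](c2ccc(/C=C/C(=O)Nc3ccccc3N)cc2)C1`: 34 mL/min/kg
Compound 2 `CN1C[C@H](C(=O)Nc2cccc(Cl)c2)[C@@H](c2ccc(/C=C/C(=O)Nc3ccccc3N)cc2)C1`: 58 mL/min/kg
Compound 3 `CN1C[C@H](C(=O)Nc2ccc(Cl)cc2F)[C@@H](c2ccc(/C=C/C(=O)Nc3ccccc3N)cc2)C1`: 43 mL/min/kg

In an in vitro ADME assay on microsomes from liver (Mus musculus) for pharmacokinetics, read by LC-MS, with a stated time of 10 min, tested at 1 uM (a higher number here means faster removal of the compound, a lower number slower removal), the three compounds sit close together, with a 1.3-fold higher number from compound 1 to compound 3 (0.10 log units; within the scatter) and a 1.3-fold lower number from compound 2 to compound 3 (0.13 log units; within the scatter), so compound 3 holds no clear rank among them. Compound 4 `CN1C[C@H](C(=O)N2CCCCC2)[C@@H](c2ccc(/C=C/C(=O)Nc3ccccc3N)cc2)C1` brings a larger change: piperidin-1-yl in place of (4-chloro-2-fluorophenyl)amino on a carbonyl carbon. In words, piperidin-1-yl takes the place of (4-chloro-2-fluorophenyl)amino on a carbonyl carbon. The measured steps, including a 1.7-fold higher number from compound 1 to compound 2 (0.23 log units; within the scatter), only exchange one substituted phenyl group for another. None of them shows what happens when that ring and the amide hydrogen go, so they are a weak guide and no clear direction can be expected. The expected step is a 1.1-fold lower number from compound 3 to compound 4 (0.05 log units; within the scatter), which is no change beyond the scatter. For compound 4 the estimate is 38 mL/min/kg, with an expected range of 17 mL/min/kg to 80 mL/min/kg.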

Compound 4, clearance: 42 mL/min/kg
For compound 4 the middle estimate is 1.1-fold (0.04 log units) below the measured one, and the stated range covers the measured number.
By their numbers in this assay, from the lowest: compounds 1, 4, 3 and 2 (each within the scatter of the next).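

Piperidin-1-yl on this carbonyl carbon removes both the substituted phenyl ring and the amide hydrogen, yet in this assay every comparison stays within the scatter, with a 1.0-fold lower number from compound 3 to compound 4 (0.01 log units; within the scatter) and a 1.4-fold lower number from compound 2 to compound 4 (0.14 log units; within the scatter) and a 1.2-fold higher number from compound 1 to compound 4 (0.09 log units; within the scatter) as the steps. At this position, then, the change from an aromatic to a non-aromatic ring shows no measurable effect on this read-out. No measurement here gives a reason for that. Still open, from the compounds shown here alone, is whether morpholin-4-yl or an open-chain group such as dimethylamino on the same carbonyl carbon would also stay within the scatter.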